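The source may hold more compounds than are shown below. What is called first, only, known or untested is meant among the compounds shown, and "the series" means these compounds.

Of the compounds shown here, three sharing one core have been measured in a functional assay (cardiac atrium) for agonist activity, with Cavia porcellus as the target; a lower number here means that less compound is needed, a higher number that more compound is needed for the effect. Compound 1 `CC1=C(C(=O)OCCO[N+](=O)[O-])C(c2cccc3nonc23)C([N+](=O)[O-])=C(C)C1` gives 31100 nM. Compound 2 `CC1=C(C(=O)OCCCCO[N+](=O)[O-])C(c2cccc3nonc23)C([N+](=O)[O-])=C(C)C1` gives 4030 nM, and compound 3 `CC1=C(C(=O)OC(C)CO[N+](=O)[O-])C(c2cccc3nonc23)C([N+](=O)[O-])=C(C)C1` gives 1860 nM, the lowest of the three numbers, with compound 2 nearest and compound 1 furthest. The change from compound 1 to compound 3 was a 17-fold lower number from compound 1 to compound 3 (1.22 log units; beyond the scatter), and the change from compound 2 to compound 3 was a 2.2-fold lower number from compound 2 to compound 3 (0.34 log units; beyond the scatter).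

Compound 4 `CC1=C(C(=O)OCC(C)O[N+](=O)[O-])C(c2cccc3nonc23)C([N+](=O)[O-])=C(C)C1` has the same atoms as compound 3, joined differently: a group of 7 heavy atoms (3 carbon, 1 nitrogen, 3 oxygen; no ring) in place of a group of 7 heavy atoms (3 carbon, 1 nitrogen, 3 oxygen; no ring), on an oxygen next to a carbonyl group. Of the measured steps, the one most relevant is the introduction of a methyl that produced a 17-fold lower number from compound 1 to compound 3 (1.22 log units; beyond the scatter), since compound 4 keeps that methyl on the chain but elsewhere along it; the step of a 2.2-fold lower number from compound 2 to compound 3 (0.34 log units; beyond the scatter) shows that small changes in this chain shift the number only modestly. A small step, likely toward a somewhat higher number, is therefore expected for compound 4, with a 1.5-fold higher number from compound 3 to compound 4 (0.18 log units; within the scatter). Compound 4 is estimated at 2800 nM, within a range from 900 nM to 9000 nM.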

Compound 4, half-maximal effective concentration: 972 nM
For compound 4 the middle estimate is 2.9-fold (0.46 log units) above the measured one; the measured number falls inside the stated range.
By their numbers in this assay, from the lowest: compounds 4 and 3 (each within the scatter of the next); then compound 2; then compound 1.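

On the oxygen next to a carbonyl group, the chains of compound 3 and compound 4 hold the same atoms joined differently, yet in this assay the two cannot be told apart, with a 1.9-fold lower number from compound 3 to compound 4 (0.28 log units; within the scatter). This shows that the methyl need not sit at one particular spot on the chain, and the new chain, 1-(nitrooxy)ethyl on the saturated carbon, also stands clear of both chains without a methyl, with a 4.1-fold lower number from compound 2 to compound 4 (0.62 log units; beyond the scatter) and a 32-fold lower number from compound 1 to compound 4 (1.51 log units; beyond the scatter). No measurement at hand offers a reason for these steps.

Still open, as far as these compounds go, is whether a chain with two methyl groups or a longer branched chain would give a lower number still. Every chain shown carries a nitrooxy group, so the result of a chain ending in a hydroxyl group instead remains unknown.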